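Ring-substituent effects on maximal response in the indane-imidazole series

The source may hold more compounds than are shown below. What is called first, only, known or untested is meant among the compounds shown, and "the series" means these compounds.

Measured compounds:
compound 1 `Cc1n[nH]cc1-c1cccc2c1CCC2c1ncc[nH]1`: 91%
compound 2 `c1cc(-c2ccn[nH]2)c2c(c1)C(c1ncc[nH]1)CC2`: 83%
compound 3 `c1ccc2c(c1)CCC2c1ncc[nH]1`: 54%

In a functional assay on CHO cells for agonist activity at Alpha-1A adrenergic receptor (Homo sapiens), read by FLIPR and calcium flux (on this read-out lower numbers stand for smaller maximal responses and higher numbers for larger maximal responses), compound 3 stands lowest of the three, its steps to compound 2 and to compound 1 both beyond the scatter. Compound 4 `CNC(=O)c1cccc2c1CCC2c1ncc[nH]1` differs from compound 3 by methylcarbamoyl in place of hydrogen on an aromatic carbon. The two steps that bear on this change run the other way: a number 37 percentage points lower from compound 1 to compound 3 (beyond the scatter) and a number 29 percentage points lower from compound 2 to compound 3 (beyond the scatter), so placing a group on this aromatic carbon has gone with a larger maximal response in both cases shown. Methylcarbamoyl is not a pyrazole, so the size is uncertain, but an increase is expected: a number 21 percentage points higher from compound 3 to compound 4 (beyond the scatter). Compound 4 is therefore estimated at 75%, within 55% to 92%.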

Compound 4, largest response reached (Emax), in percent of the reference or control that the assay uses: 59%
Beside the measured number, compound 4's estimate is 16 percentage points above it; measured number inside the range.
By their numbers in this assay, from the lowest: compounds 3 and 4 (each within the scatter of the next); then compounds 2 and 1 (each within the scatter of the next).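

In this assay, a group on this aromatic carbon does not by itself go with a larger maximal response (a number 5 percentage points higher from compound 3 to compound 4 (within the scatter)). Methylcarbamoyl instead separates from both pyrazoles (a number 24 percentage points lower from compound 2 to compound 4 (beyond the scatter); a number 32 percentage points lower from compound 1 to compound 4 (beyond the scatter)). The rise seen so far therefore holds for the two pyrazole groups, while methylcarbamoyl goes against it. No measurement that could explain this difference is available. As far as these compounds go, whether an amine, a carboxylic acid or a phenyl group on this carbon would stand with the pyrazoles or with methylcarbamoyl remains open.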